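Swapping an ester for an oxime at the far end

The compounds below may be only part of what the source reports. "The series", "measured", "known", "first", "only" and "open" are said of these compounds alone.

Of the compounds shown here, three built on one shared core have so far been measured in a functional assay on cells (Platelet, Homo sapiens) for inhibition; on this read-out lower numbers stand for stronger inhibition and higher numbers for weaker inhibition. Compound 1 `CCOC(=O)c1ccc(-c2nn(Cc3cccnc3)c3ccccc23)cc1` gives 5550 nM. Compound 2 `CCOC(=O)c1ccc(-c2nn(Cc3ccncc3)c3ccccc23)cc1` gives 5630 nM. Among the measured compounds shown here, the single step between them, a 1.0-fold higher number from compound 1 to compound 2 (0.01 log units; within the scatter), changes only where the ring nitrogen sits on the pendant ring. Compound 3 `COC(=O)c1ccc(-c2nn(Cc3ccccc3)c3ccccc23)cc1` gives 560 nM and stands lowest of the three; its distance to compound 1 and to compound 2 is in each case beyond the scatter, so compound 3 is the strongest inhibitor measured here.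

Compound 4 `CO/N=C\c1ccc(-c2nn(Cc3ccccc3)c3ccccc23)cc1` is not yet measured. Compared with compound 3 it carries the change (a group of 4 heavy atoms (2 carbon, 1 nitrogen, 1 oxygen; no ring) in place of a group of 4 heavy atoms (2 carbon, 2 oxygen; no ring), on an aromatic carbon). For the measured compounds named here, no measured step touches this position: the only step in hand, from compound 1 to compound 2, alters the pendant ring and says nothing about the group that leaves or the group that enters. What can be said is that the two groups match in size and in the count of acceptors, which argues for a modest rather than a large shift. The expected step is therefore a 1.6-fold higher number from compound 3 to compound 4 (0.21 log units; within the scatter), in either direction, and compound 4 is estimated at 900 nM, within a range from 250 nM to 3500 nM.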

Compound 4, half-maximal inhibitory concentration: > 10000 nM
Compound 4: no number, only a limit; the forecaster's own chance of this, stated with the estimate: 5%; at least 11-fold (1.04 log units) between middle value and limit.
By their numbers in this assay, from the lowest: compound 3; then compounds 1 and 2 (each within the scatter of the next). At a limit, above all of these: compound 4.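

In this assay compound 4 gives no number, only a limit: the limit of > 10000 nM in this assay, at which 1 of the 4 values shown sits.

Among the compounds shown here, putting the oxime in place of methoxycarbonyl, on an aromatic carbon para to a large group, gives an at least 17-fold higher number from compound 3 to compound 4 (1.25 log units; beyond the scatter), so this position, which no earlier step had touched, is far from indifferent to what it carries. The two groups have the same count of heavy atoms and of hydrogen-bond acceptors, and neither has a ring or a net charge, so for this pair a match on those counts did not keep the inhibition seen with the ester.

The compounds shown do not tell which difference between the two groups matters, nor how far beyond the limit the true value of compound 4 lies. They also leave open how this same position would respond to a carboxylic acid, a primary amide or a simple ketone, and whether the oxime with the opposite geometry at its double bond would behave as compound 4 does.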